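The compounds below may be only part of what the source reports. "The series", "measured", "known", "first", "only" and "open" are said of these compounds alone.

Three compounds have so far been followed in an ADME assay on a cell-free system (plasma, Mus musculus) for metabolic stability, tested at 1 uM; a lower number here means that the compound disappears faster, a higher number that the compound lasts longer: compound 1 `C=CC(=O)N1CCN(S(=O)(=O)c2ccc(NC(=O)OCc3ccccc3)cc2)CC1`, compound 2 `C=CC(=O)N[C@H]1CCCN(S(=O)(=O)c2ccc(NC(=O)OCc3ccccc3)cc2)C1` and compound 3 `C=CC(=O)NC1CCN(S(=O)(=O)c2ccc(C(=O)NCc3ccccc3)cc2)CC1`. Compound 1 gives > 6 h, which is a limit of the assay and not a number. Compound 2 gives > 6 h, again a limit. Compound 3 gives > 6 h, also a limit and not a number, so it has no exact half-life of its own and shares its place with the other two: the limit of > 6 h in this assay, at which 3 of the 3 values shown sit.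

The next compound is compound 4 `C=CC(=O)NC1CCN(S(=O)(=O)c2ccc(C(=O)NCCCc3ccccc3)cc2)CC1`, which differs from compound 3 in one place: phenethyl in place of phenyl on a saturated chain carbon bound to an amide-type nitrogen. Cut one bond further out, this reads benzyl to 3-phenylpropyl. Among the compounds with values here, no measured pair shows the effect of such a change, so the expectation rests on compound 3 and its neighbours, and no shift beyond the scatter is expected because of the limit of > 6 h in this assay, at which 3 of the 3 values shown sit. The expected size is a step that the limit leaves unreadable from compound 3 to compound 4, in no clear direction. Compound 4 is estimated at 7 h, with an expected range from 4 h to 12 h.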

Compound 4, half-life: > 6 h
Compound 4: no number, only a limit; the forecaster's own chance of this, stated with the estimate: 85%; the middle value is on the limit's open side.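

In this assay compound 4 gives > 6 h, a limit and not a number. Compound 3 also stands at a limit, so no step can be read between compound 3 and compound 4. The compounds shown leave open what the exact half-life of any of them is and which structural change would bring one within readable range.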